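From 2-fluorobenzyl to 2-chlorobenzyl on a shared core

This account rests on a few compounds, and the source may have more. Where it says the series, first, only, none or still open, it means among the compounds named here.

Values in a functional assay on DU-145 cells (Homo sapiens) for cytotoxicity, read by MTT assay, with a stated time of 24 h; on this read-out higher numbers stand for weaker inhibition and lower numbers for stronger inhibition
Compound 1 `Cc1ccc(/C=C2\CN(Cc3cn(Cc4cccc(Cl)c4)nn3)C/C(=C\c3ccc(C)cc3)C2=O)cc1` gives 33100 nM
Compound 2 `Cc1ccc(/C=C2\CN(Cc3cn(Cc4ccccc4F)nn3)C/C(=C\c3ccc(C)cc3)C2=O)cc1` gives 9500 nM

Of these two, compound 2 has the lower number. Compound 3 `Cc1ccc(/C=C2\CN(Cc3cn(Cc4ccccc4Cl)nn3)C/C(=C\c3ccc(C)cc3)C2=O)cc1` differs from it by chloro in place of fluoro on an aromatic carbon. Going by the values given here, only one measured step bears on this change: a 3.5-fold lower number from compound 1 to compound 2 (0.54 log units; beyond the scatter). That step also moves from 3-chlorophenyl to 2-fluorophenyl, so it does not compare the two halogens at one place. Among the compounds with values here, compound 1, the only measured chloro compound, gives 33100 nM, so a small step toward a higher number is expected in this assay, possibly not beyond the scatter. The expected change is a 1.7-fold higher number from compound 2 to compound 3 (0.23 log units; within the scatter). Compound 3 is estimated at 16000 nM, with an expected range of 6500 nM to 38000 nM.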

Compound 3, half-maximal inhibitory concentration: 10500 nM
Beside the measured number, compound 3's estimate is 1.5-fold (0.18 log units) above it; low and high end bracket the measured number.
By their numbers in this assay, from the lowest: compounds 2 and 3 (each within the scatter of the next); then compound 1.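

In this assay, chloro in place of fluoro on this aromatic carbon gives a 1.1-fold higher number from compound 2 to compound 3 (0.04 log units; within the scatter), so the two halogens cannot be told apart here. The chloro group can now be compared at two places on the ring: 2-chlorophenyl in place of 3-chlorophenyl gives a 3.2-fold lower number from compound 1 to compound 3 (0.50 log units; beyond the scatter), a step beyond the scatter. No evidence is available to explain either result. The compounds shown leave open whether a methoxy group or an amine on this same aromatic carbon would read like the two halogens, and whether 3-fluorophenyl would follow 3-chlorophenyl.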